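The source may hold more compounds than are shown below. What is called first, only, known or untested is meant among the compounds shown, and "the series" means these compounds.

Measured so far:
- compound 1 `COP(=O)(OC[C@H]1OC(n2ccc(N)nc2=O)[C@@H](O)[C@@H]1O)OCC(Cl)(Cl)Cl`: 22%
- compound 2 `Nc1ccn(C2O[C@H](COP(=O)(OCC(Cl)(Cl)Cl)OCC(Cl)(Cl)Cl)[C@@H](O)[C@@H]2O)c(=O)n1`: 91%

In an assay on cells (Epithelial cell) with Nucleic Acid as the target, tested at 30 uM (on this read-out higher numbers stand for more inhibition at the one concentration tested (going by the name of the read-out) and lower numbers for less inhibition), compound 2 gives 91%, the highest of the two numbers; compound 1 gives 22%. Going by the values given here, the only step recorded is a number 69 percentage points higher from compound 1 to compound 2 (beyond the scatter). Compound 3 `CCCOP(=O)(OC[C@H]1OC(n2ccc(N)nc2=O)[C@@H](O)[C@@H]1O)OCC(Cl)(Cl)Cl` differs from compound 2 by ethyl in place of trichloromethyl on a saturated chain carbon bound to an oxygen. This change runs counter to the recorded step: it removes one of the two trichloromethyl groups whose introduction into compound 1 accompanied the large rise, so a large fall back toward compound 1 is expected. The expected step is a number 56 percentage points lower from compound 2 to compound 3 (beyond the scatter), a large drop, and compound 3 is estimated at 35% with a range of 10% to 70%.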

Compound 3, a percentage reported as inhibition, at one concentration (the size of the read-out at that concentration, not a potency): 40%
Compound 3: middle estimate off by 5 percentage points, on the low side; measured number inside the range.
By their numbers in this assay, from the lowest: compound 1; then compound 3; then compound 2.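

In this assay the change from 2,2,2-trichloroethyl to propyl gives a number 51 percentage points lower from compound 2 to compound 3 (beyond the scatter) and so the high reading of compound 2 is not kept with this unchlorinated chain. Propyl nevertheless gives a number 18 percentage points higher from compound 1 to compound 3 (beyond the scatter) so a rise over compound 1 at this position does not require a second trichloromethyl group. Nothing available here accounts for either step.

Open, from the compounds shown here alone, is whether a longer chain would extend the gain seen with propyl. Also open, going by these compounds, is how 2,2,2-trifluoroethyl, an amine or a carboxylic acid at this position would compare with 2,2,2-trichloroethyl.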